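This account rests on a few compounds, and the source may have more. Where it says the series, first, only, none or still open, it means among the compounds named here.

In a functional assay on SK-OV-3 cells (Homo sapiens) for antiproliferative activity, read by MTT assay, with a stated time of 24 h (a lower number here means a stronger inhibitor, a higher number a weaker inhibitor), compound 3 `COc1ccc(C(=O)/C=C/c2ccc([N+](=O)[O-])cc2)c2c1C=CC(C)(C)O2` gives 3420 nM, and compound 1 `COc1ccc(/C=C/C(=O)c2ccc(OC)c3c2OC(C)(C)C=C3)c(F)c1` gives 4880 nM. These two values sit close together, with a step of a 1.4-fold lower number from compound 1 to compound 3 (0.15 log units; within the scatter). Compound 2 `COc1ccc(C(=O)/C=C/c2cccc(F)c2)c2c1C=CC(C)(C)O2` reaches only a limit of the assay, > 10000 nM. Set against that limit, the measured step is an at least 2.9-fold lower number from compound 2 to compound 3 (0.46 log units; beyond the scatter), and the step between the other pair is an at least 2.0-fold higher number from compound 1 to compound 2 (0.31 log units; beyond the scatter).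

Compound 4 `COc1ccc(C(=O)/C=C/c2ccsc2)c2c1C=CC(C)(C)O2` keeps the shared core and puts thiophen-3-yl in place of 4-nitrophenyl, on a double-bonded chain carbon bound to a double-bonded chain carbon: thiophen-3-yl in place of 4-nitrophenyl on a double-bonded chain carbon bound to a double-bonded chain carbon. For the measured compounds named here, no measured compound carries thiophen-3-yl, so the only guide is the three steps that swap groups at this same place. Compound 1 shows that leaving 4-nitrophenyl can cost little, while compound 2 shows that it can cost more, so a modest move toward a higher number seems the likeliest outcome. The expected step is a 2.0-fold higher number from compound 3 to compound 4 (0.31 log units; beyond the scatter). For compound 4, the estimated value is 7000 nM, with an expected range from 3000 nM to 16000 nM.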

Compound 4, half-maximal inhibitory concentration: > 10000 nM
Compound 4: no number, only a limit (the forecaster's own chance of this, stated with the estimate: 35%); middle value at least 1.4-fold (0.15 log units) from the limit.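

In this assay, moving from 4-nitrophenyl to thiophen-3-yl at this place on the chain gives an at least 2.9-fold higher number from compound 3 to compound 4 (0.46 log units; beyond the scatter) and, against the other measured compound, an at least 2.0-fold higher number from compound 1 to compound 4 (0.31 log units; beyond the scatter) at the same place. For the compounds shown here, the earlier compounds carried only phenyl rings here, so this is the first look at a five-membered aromatic ring with a sulfur atom, and it gives no measured number, although compound 2 shows that a phenyl ring does not ensure one either. Compound 4 and compound 2 both stop at a limit, so the step between them cannot be read: the limit of > 10000 nM in this assay, at which 2 of the 4 values shown sit.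

Going by these compounds, whether any ring other than a phenyl ring can give a measured number at this place stays open. A pyridine or furan ring, or a phenyl ring carrying an amine or a carboxylic acid, would test that.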